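The source may hold more compounds than are shown below. What is called first, only, known or untested is meant among the compounds shown, and "the series" means these compounds.

Compound 1 `CCCc1nc(C)c2c(C(C)C)nnc(O)n12` gives in a functional assay for inhibition, with Homo sapiens as the target (a higher number here means a weaker inhibitor, a lower number a stronger inhibitor), a limit of > 48000 nM.
Compound 2 `CCCc1nc(C)c2c(-c3ccccc3)nnc(SC)n12` gives in this assay a limit of > 48000 nM.
Compound 3 `CCCc1nc(C)c2c(C)nnc(SC)n12` gives in this assay a limit of > 48000 nM.

Compound 3 thus stands where every measured compound stands, at the limit of the method, which is described by the limit of > 48000 nM in this assay, at which 3 of the 3 values shown sit. Among the compounds with values here, the only measured step that touches compound 3 is a step that the two limits leave unreadable from compound 2 to compound 3, and since both ends of that step are limits its size cannot be read. Compound 4 `CCCc1nc(C)c2c(C(C)C)nnc(SC)n12` differs from compound 3 by isopropyl in place of methyl on an aromatic carbon. Within the data shown here, no measured step with a readable size bears on this change, so no direction can be predicted, and the three limits give no ground to expect a readable value. Compound 4 is therefore estimated at 70000 nM, within 20000 nM to 250000 nM, an expected step that the limit leaves unreadable from compound 3 to compound 4.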

Compound 4, half-maximal inhibitory concentration: > 48000 nM
Compound 4: a limit, no number; the forecaster's own chance of this, stated with the estimate: 85%; the middle value lies beyond the limit too.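

Compound 4 also gives only a limit in this assay, so no step from compound 1, compound 2 or compound 3 to compound 4 can be read: the limit of > 48000 nM in this assay, at which 4 of the 4 values shown sit.

The compounds shown leave open which change to the shared core, if any, would bring a readable inhibition.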